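Swapping methoxy for nitro at the assay limit

The source may hold more compounds than are shown below. What is called first, only, known or untested is meant among the compounds shown, and "the series" means these compounds.

In a functional assay on BEL-7404 cells (Homo sapiens) for cytotoxicity, read by MTT assay, with a stated time of 72 h (a higher number here means a weaker inhibitor, a lower number a stronger inhibitor), compound 1 `COc1ccc(/C=C/C(=O)OC/C=C/c2ccc(OC)c(OC)c2)cc1` gives > 100 ug/mL, which is a limit of the assay and not a number. Compound 2 `COCOc1ccc(/C=C/C(=O)OC/C=C/c2ccc(OC)cc2)cc1` gives > 100 ug/mL, also only a limit. Compound 3 `COc1ccc(/C=C/COC(=O)/C=C/c2ccc([N+](=O)[O-])cc2)cc1OC` keeps the core of compound 1 but carries nitro in place of methoxy on an aromatic carbon, para to a large group: nitro in place of methoxy on an aromatic carbon. For the measured compounds named here, no measured step guides this change, so only a slight strengthening in this assay, perhaps none beyond the scatter, is expected: an at least 1.2-fold lower number from compound 1 to compound 3 (0.09 log units; that floor lies within the scatter). For compound 3 the estimated value is 80 ug/mL, with an expected range from 25 ug/mL to 200 ug/mL.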

Compound 3, half-maximal inhibitory concentration: > 100 ug/mL
Compound 3 was reported as a limit (the forecaster's own chance of this, stated with the estimate: 55%); at least 1.2-fold (0.09 log units) between middle value and limit.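

Nitro in place of methoxy gives no readable step between compound 1 and compound 3, since neither compound has a number, only a limit: the limit of > 100 ug/mL in this assay, at which 3 of the 3 values shown sit. On these data alone, the true values of compound 1, compound 2 and compound 3 stay open, and so does whether this swap changes anything.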